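Nucleoside series: thiocyanate to dithiolane swap, cytotoxicity outlook

The source may report more compounds than this note shows. Statements on the series, on what has been measured and on what is new or still open speak of the compounds shown alone.

Three compounds carry values in an ADME assay on L1210/0 cells (Mus musculus) for cytotoxicity, with a stated time of 48 h; a lower number here means a stronger inhibitor, a higher number a weaker inhibitor. Compound 1 `Oc1ncnc2c1ncn2C[C@@H]1C[C@H](O)c2ccccc21` reports only a limit of the assay, > 200000 nM. Compound 3 `Nc1ncnc2c1ncn2C[C@@H]1C[C@H](CO)c2ccccc21` likewise sits at a limit, > 200000 nM. Among the compounds with values here, compound 2 `N#CSc1cn([C@H]2C[C@H](O)[C@@H](CO)O2)c(=O)[nH]c1=O` is the one compound with an actual number: in this assay compound 2 gives 78900 nM. Compound 2 thus stands as the sole numeric point in the set, the remaining two entries resting at the limit of > 200000 nM in this assay, at which 2 of the 3 values shown sit.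

Compound 4 `O=c1[nH]c(=O)n([C@H]2C[C@H](O)[C@@H](CO)O2)cc1C1SCCS1` has not yet been measured. It differs from compound 2 at a single site: a group of 5 heavy atoms (3 carbon, 2 sulfur; one five-membered non-aromatic ring with 2 hetero atoms) in place of a group of 3 heavy atoms (1 carbon, 1 nitrogen, 1 sulfur; no ring), on an aromatic carbon. Within the data shown here, no step between two measured compounds is available to gauge a change of this kind, so the outlook rests on compound 2 alone.

The step of a 1.5-fold higher number from compound 2 to compound 4 (0.18 log units; within the scatter) is expected to be small, leaning toward weaker inhibition, and quite possibly none beyond the usual scatter. Compound 4 is therefore estimated at about 120000 nM, with a range from 30000 nM to 400000 nM, and a limit rather than a number is a real possibility.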

Compound 4, half-maximal inhibitory concentration: > 200000 nM
Compound 4 gave a limit, no number; the forecaster's own chance of this, stated with the estimate: 40%; at least 1.6-fold (0.22 log units) between middle value and limit.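

In this assay, replacing cyanosulfanyl with the five-membered non-aromatic ring with 2 hetero atoms on this aromatic carbon gives an at least 2.5-fold higher number from compound 2 to compound 4 (0.40 log units; beyond the scatter). Within the data shown here, this is the first reading of a change at this position, and it shows that the measurable value of compound 2 is lost although the counts of hydrogen-bond donors and acceptors are the same in both groups. Compound 4 gives a limit, not a number, so the step has only a lower bound and compound 2 remains the sole numeric point in the set: the limit of > 200000 nM in this assay, at which 3 of the 4 values shown sit.

On these data alone, how far compound 4 lies beyond its limit stays open. Also open, as far as these compounds go, is whether the value of compound 2 depends specifically on cyanosulfanyl, or whether an amine or a carboxylic acid on the same carbon would also give a number.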